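A few compounds are considered here, and "the series" means these few. Any claim that something is new, unique, unknown or untested is made for them only; others in the source may bear on it.

Measured in a functional assay on MGC-803 cells (Homo sapiens) for inhibition, read by sulforhodamine B assay; on this read-out lower numbers stand for stronger inhibition and higher numbers for weaker inhibition:
compound 1 `O=C1C(Nc2ccccc2)=CC(=O)c2c1nc1n2[C@H]2OC[C@@H](O)[C@H]2OC1` — 1830 nM
compound 2 `O=C1C=C(Nc2ccc(Br)cc2)C(=O)c2c1nc1n2[C@H]2OC[C@@H](O)[C@H]2OC1` — 1010 nM

Compound 1 holds the higher of the two numbers, but its gap to compound 2 lies within the scatter, so the pair reads as equivalent. Compound 3 `O=C1C(Nc2cccc(Cl)c2)=CC(=O)c2c1nc1n2[C@H]2OC[C@@H](O)[C@H]2OC1` is still to be measured in this assay. It differs from compound 1 by chloro in place of hydrogen on an aromatic carbon. No step between measured compounds calibrates this exchange on the anilino ring; on the two numbers shown it is expected to move the read-out little, if at all. The expected step is a 1.3-fold lower number from compound 1 to compound 3 (0.12 log units; within the scatter), not beyond the scatter. Compound 3 is estimated at 1400 nM, within 500 nM to 3800 nM.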

Compound 3, half-maximal inhibitory concentration: 1530 nM
The estimate for compound 3 lay 1.1-fold (0.04 log units) below the measured number; the measured number falls inside the stated range.
By their numbers in this assay, from the lowest: compounds 2, 3 and 1 (each within the scatter of the next).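

In this assay, chloro in place of hydrogen on an aromatic carbon, meta to a large group, gives a 1.2-fold lower number from compound 1 to compound 3 (0.08 log units; within the scatter). Within the data shown here, this is the first calibrated exchange on the anilino ring: at this position, a single chlorine atom leaves the read-out indistinguishable from that of hydrogen. No measurement is available that accounts for this result.

From the compounds shown here alone, whether a larger or differently built group at this position, such as an amine, a carboxylic acid or a methoxy group, would separate from hydrogen remains open. Also open, going by these compounds, is whether chloro elsewhere on the anilino ring would behave the same way.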